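A Single Ring Swap on Compound 1

The source may report more compounds than this note shows. Statements on the series, on what has been measured and on what is new or still open speak of the compounds shown alone.

In a functional assay on A549 cells (Homo sapiens) for inhibition, read by sulforhodamine B assay, with a stated time of 72 h (a lower number here means a stronger inhibitor, a higher number a weaker inhibitor), compound 1 `CC1CCN(C(=O)c2c(N)sc(-c3ccc(Cl)cc3)c2-c2ccc(Cl)cc2)CC1` gives 1750 nM, the lower of the two numbers available. Compound 2 `CCOC(=O)Nc1sc(-c2ccc(Cl)cc2)c(-c2ccc(Cl)cc2)c1C(=O)NC1CC1` gives 39800 nM, a gap beyond the usual scatter, and compound 3 `CCN(CC)CCNC(=O)Nc1sc(-c2ccc(Cl)cc2)c(-c2ccc(Cl)cc2)c1C(=O)NC1CC1` is recorded as "not determined" (no result reported). Compound 4 `CN1CCN(C(=O)c2c(N)sc(-c3ccc(Cl)cc3)c2-c2ccc(Cl)cc2)CC1` keeps the core of compound 1 and changes one group: 4-methylpiperazin-1-yl in place of 4-methylpiperidin-1-yl on a carbonyl carbon. Among the measured compounds shown here, no measured pair of compounds shows this change on its own, so any forecast is uncertain. A modest move towards weaker inhibition in this assay is the expectation, estimated as a 2.6-fold higher number from compound 1 to compound 4 (0.41 log units; beyond the scatter). Compound 4 is expected to give about 4500 nM, with an estimated range of 1500 nM to 14000 nM.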

Compound 4, half-maximal inhibitory concentration: 590 nM
Estimate against measurement, compound 4: 7.6-fold (0.88 log units) above; measured number below the stated range.
By their numbers in this assay, from the lowest: compound 4; then compound 1; then compound 2.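

In this assay the group on this carbonyl carbon clearly affects the result: 4-methylpiperazin-1-yl in place of 4-methylpiperidin-1-yl gives a 3.0-fold lower number from compound 1 to compound 4 (0.47 log units; beyond the scatter) and so shows that a second ring nitrogen here is accepted and goes with stronger inhibition. Compound 2 and compound 3 differ from compound 1 in more than one place, so they could not isolate this change. No measurement here explains the gain. Still open, going by these compounds, is whether the ring nitrogen or its methyl group matters more; an unsubstituted piperazin-1-yl, a morpholin-4-yl or a longer chain on that nitrogen would help separate them.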